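The compounds below may be only part of what the source reports. "The series", "measured", "known", "first", "only" and "open" are said of these compounds alone.

Measured so far:
- compound 1 `c1cnc2c(c1)CCC[C@@H]2N(CCCN1CCNCC1)Cc1nc2ccccc2s1` — 50%
- compound 2 `c1ccc2c(c1)CN[C@H](CN(CCCN1CCNCC1)[C@H]1CCCc3cccnc31)C2` — 99%
- compound 3 `CC(C)N1CCN(CCCN(C[C@H]2Cc3ccccc3CN2)[C@H]2CCCc3cccnc32)CC1` — 46%

In an ADME assay on microsomes from liver (Homo sapiens) for metabolic stability, read by LC-MS, with a stated time of 10 min, tested at 0.5 uM (a lower number here means that less of the compound is left, a higher number that more of the compound is left), compound 3 and compound 1 lie within the scatter of each other, while compound 2 sits far above both. Among the measured compounds shown here, the only single-point step in hand is a number 49 percentage points higher from compound 1 to compound 2 (beyond the scatter), which concerns the group on the saturated chain carbon bound to the amine nitrogen, not the end of the chain changed here.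

Compound 4 `c1ccc2c(c1)CN[C@@H](CN(CC[C@@H]1CCCNC1)[C@H]1CCCc3cccnc31)C2` differs from compound 3 by piperidin-3-yl in place of (4-isopropylpiperazin-1-yl)methyl on a saturated chain carbon, two bonds along the chain from an amine nitrogen. For the measured compounds named here, no measured step covers this change, so the expectation rests only on compound 2, whose 99% shows that a chain end carrying a free ring amine is compatible with high remaining compound, and on compound 3 with 46%. Compound 4 is therefore expected to come out above compound 3, a step of about a number 22 percentage points higher from compound 3 to compound 4 (beyond the scatter), though the direction is uncertain. Compound 4 is estimated at 68%, with a range of 40% to 95%.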

Compound 4, percent of the compound remaining: 75%
Compound 4: the middle estimate sits 7 percentage points below what was measured; measured number inside the range.
By their numbers in this assay, from the lowest: compounds 3 and 1 (each within the scatter of the next); then compound 4; then compound 2.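

In this assay, the chain end proves able to move the read-out on its own: piperidin-3-yl in place of (4-isopropylpiperazin-1-yl)methyl gives a number 29 percentage points higher from compound 3 to compound 4 (beyond the scatter) at this place, two bonds along the chain from an amine nitrogen. Among the compounds shown here, the only earlier step lay elsewhere, so this is the first reading for this position. The change alters ring, size and hydrogen-bond donors together, and nothing on hand explains the step. On these data alone, whether a piperidin-4-yl or a methyl on the piperidine nitrogen would keep this gain stays open.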